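A Hydroxyethyl Chain in Place of Isopropyl

A few compounds are considered here, and "the series" means these few. Any claim that something is new, unique, unknown or untested is made for them only; others in the source may bear on it.

Of the compounds shown here, three sharing one core have been tested in a functional assay on the whole organism with Mus musculus as the target, in the writhing test; on this read-out higher numbers stand for an effect only at larger amounts of compound and lower numbers for an effect already at smaller amounts. Compound 1 `Cc1cc(=O)oc2c1c(C)nn2C` gives 11.6 mg/kg, and compound 2 `CCn1nc2oc(=O)cc(C)c2c1C` gives 14.6 mg/kg. Compound 3 `Cc1cc(=O)oc2nn(C(C)C)c(C)c12` gives 35.3 mg/kg, the highest number of the three, standing beyond the scatter above both others. For the measured compounds named here, the only single-point step measured is a 2.4-fold higher number from compound 2 to compound 3 (0.38 log units; beyond the scatter), a modest shift upward when methyl replaces hydrogen on the saturated chain carbon bound to the aromatic nitrogen.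

Compound 4 `Cc1cc(=O)oc2nn(CCO)c(C)c12` has not been measured. It differs from compound 3 in one place: 2-hydroxyethyl in place of isopropyl on an aromatic nitrogen. Going by the values given here, no measured step introduces a hydroxyl group, so the existing data bear on this change only indirectly. Going by these compounds, the step of a 2.4-fold higher number from compound 2 to compound 3 (0.38 log units; beyond the scatter) indicates that branching the chain on this nitrogen raised the number; compound 4 returns to an unbranched chain of the same length as ethyl, as in compound 2 with 14.6 mg/kg, but carries a hydroxyl group whose influence is untested here. The expectation is therefore a number near that of compound 2, with wide uncertainty. Compound 4 is expected to give 18 mg/kg, within a range from 8 mg/kg to 40 mg/kg, which means an expected step of a 2.0-fold lower number from compound 3 to compound 4 (0.29 log units; within the scatter).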

Compound 4, dose for half-maximal effect: > 100 mg/kg
Compound 4: no number, only a limit; the forecaster's own chance of this, stated with the estimate: 10%; middle value at least 5.5-fold (0.74 log units) from the limit.
By their numbers in this assay, from the lowest: compounds 1 and 2 (each within the scatter of the next); then compound 3. At a limit, above all of these: compound 4.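

In this assay compound 4 has a limit of the assay and not a number: the limit of > 100 mg/kg in this assay, at which 1 of the 4 values shown sits.

Even so, the position on the aromatic nitrogen proves more sensitive than the earlier compounds showed, since 2-hydroxyethyl in place of isopropyl gives an at least 2.8-fold higher number from compound 3 to compound 4 (0.45 log units; beyond the scatter), so the unbranched chain does not bring the number back towards that of the ethyl compound. Placing hydroxy on the saturated chain carbon, two bonds along the chain from the aromatic nitrogen, gives an at least 6.8-fold higher number from compound 2 to compound 4 (0.83 log units; beyond the scatter), a larger shift than the one from adding methyl to the chain, a 2.4-fold higher number from compound 2 to compound 3 (0.38 log units; beyond the scatter), and so the change with the largest effect in this small set is the hydroxy, not the branching.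

A 2-methoxyethyl chain, a longer 3-hydroxypropyl chain or a 2-aminoethyl chain on this nitrogen would show whether the rise follows the hydroxyl hydrogen, any oxygen or nitrogen on the chain, or the exact distance from the ring. Going by these compounds, how far the true value of compound 4 lies past its limit also remains open, so the full size of both new steps is unknown.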